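Hydroxydimethylphenyl Replaces Dichlorophenyl on the Hydrazone Carbon

The compounds below may be only part of what the source reports. "The series", "measured", "known", "first", "only" and "open" are said of these compounds alone.

Compound 3 `CN(C)CCn1cnnc1-c1cc(Oc2ccc(NC(=O)N/N=C/c3cccc(Cl)c3Cl)cc2F)ccn1` gives 51 nM in a functional assay on MKN-45 cells (Homo sapiens) for cytotoxicity, read by MTT assay, with a stated time of 72 h (on this read-out higher numbers stand for weaker inhibition and lower numbers for stronger inhibition), the lowest of the three numbers recorded. Compound 1 `CN(C)CCn1cnnc1-c1cc(Oc2ccc(NC(=O)N/N=C/c3ccccc3O[N+](=O)[O-])cc2F)ccn1` gives 1020 nM in this assay, and compound 2 `CN(C)CCn1cnnc1-c1cc(Oc2ccc(NC(=O)N/N=C/c3ccc(F)cc3)cc2F)ccn1` gives 1030 nM. The two steps reaching compound 3 are both large: a 20-fold lower number from compound 1 to compound 3 (1.30 log units; beyond the scatter), and a 20-fold lower number from compound 2 to compound 3 (1.31 log units; beyond the scatter). By contrast, a 1.0-fold higher number from compound 1 to compound 2 (0.00 log units; within the scatter), so the two aryl groups other than 2,3-dichlorophenyl behave alike.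

Compound 4 `Cc1cc(/C=N/NC(=O)Nc2ccc(Oc3ccnc(-c4nncn4CCN(C)C)c3)c(F)c2)cc(C)c1O` has not yet been measured. It differs from compound 3 in one place: 4-hydroxy-3,5-dimethylphenyl in place of 2,3-dichlorophenyl on a carbon with a double bond to nitrogen. Within the data shown here, no measured step bears directly on 4-hydroxy-3,5-dimethylphenyl. What the measured steps do show is that two different aryl groups both sit far from compound 3, with only 2,3-dichlorophenyl giving the low number. The step from compound 3 to compound 4 is therefore expected to go toward higher numbers, and the size expected is a 7.8-fold higher number from compound 3 to compound 4 (0.89 log units; beyond the scatter). Compound 4 is estimated at 400 nM in this assay, with a range from 100 nM to 2000 nM.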

Compound 4, half-maximal inhibitory concentration: 1510 nM
Beside the measured number, compound 4's estimate is 3.8-fold (0.58 log units) below it, and the stated range covers the measured number.
By their numbers in this assay, from the lowest: compound 3; then compounds 1, 2 and 4 (each within the scatter of the next).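

In this assay the change gives a 30-fold higher number from compound 3 to compound 4 (1.47 log units; beyond the scatter) and so adds a third aryl group on the carbon with a double bond to nitrogen that fails to keep the low number of 2,3-dichlorophenyl. The new group also shows no separation from the other two, with a 1.5-fold higher number from compound 2 to compound 4 (0.17 log units; within the scatter) and a 1.5-fold higher number from compound 1 to compound 4 (0.17 log units; within the scatter) as its steps, so this hydroxy-bearing, dimethyl-substituted ring, with its hydrogen-bond donor, falls in the same band as 4-fluorophenyl and 2-(nitrooxy)phenyl. Nothing given here explains why 2,3-dichlorophenyl alone stands apart among these four compounds.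

From the compounds shown here alone, whether both chlorines are needed for the low number stays open, as a ring with a single chlorine would be required to tell. Also open, going by these compounds, is whether two bromine atoms or two methyl groups in place of the chlorines would keep it.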